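The source may hold more compounds than are shown below. What is called first, only, known or untested is meant among the compounds shown, and "the series" means these compounds.

Compound 1 `CCCCCC(=O)Nc1cc2nc(C3CCCCC3)[nH]c2cc1N1CCCC1` is the reference point of the series in an ADME assay on Vero cells (Chlorocebus sabaeus) for cytotoxicity, read by resazurin assay, with a stated time of 3 days; on this read-out higher numbers stand for weaker inhibition and lower numbers for stronger inhibition. In this assay compound 1 gives only a limit, > 100 ug/mL. Compound 2 `CCCCCC(=O)Nc1cc2nc(C3CCCCC3)[nH]c2cc1N(CC)CC` is recorded in this assay as "not determined" (no result reported). No step between measured compounds can be drawn; on the numbers shown, compound 1 stands at the limit of > 100 ug/mL in this assay, at which 1 of the 2 values shown sits. Compound 3 `COc1ccc(C(=O)Nc2cc3nc(C4CCCCC4)[nH]c3cc2N2CCCC2)cc1` differs from compound 1 by 4-methoxyphenyl in place of pentyl on a carbonyl carbon. In this assay the expected change is an at least 1.1-fold lower number from compound 1 to compound 3 (0.04 log units; that floor lies within the scatter), none beyond the scatter. Compound 3 is therefore expected to give about 90 ug/mL, between 30 ug/mL and 250 ug/mL, with a limit rather than a number likely again.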

Compound 3, half-maximal inhibitory concentration: > 100 ug/mL
Compound 3 was reported as a limit; the forecaster's own chance of this, stated with the estimate: 60%; at least 1.1-fold (0.04 log units) between middle value and limit.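

Compound 1 and compound 3 are both reported only as limits in this assay, and no step can be read between them. Still open, from the compounds shown here alone, is whether pentyl and 4-methoxyphenyl on the carbonyl carbon differ at all on this read-out.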